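The source may report more compounds than this note shows. Statements on the series, on what has been measured and on what is new or still open speak of the compounds shown alone.

Going by the values given here, in an ADME assay on Vero cells (Chlorocebus sabaeus) for antiproliferative activity, read by MTT assay (on this read-out lower numbers stand for stronger inhibition and higher numbers for weaker inhibition), compound 2 `COc1cc(OC)c(-c2nc(N3CCN(C)CC3)nc3ccccc23)c(OC)c1` gives 50 ug/mL and stands level with compound 1 `COc1ccc(-c2nc(N3CCNCC3)nc3ccccc23)c(OC)c1` at 50 ug/mL and compound 3 `COc1cc(OC)c(-c2nc(N3CCNCC3)nc3ccccc23)c(OC)c1` at 50 ug/mL on the numbers so far. Compound 4 `COc1ccc(-c2nc(N3CCN(C)CC3)nc3ccccc23)c(OC)c1` is still unmeasured and differs from compound 2 by hydrogen in place of methoxy on an aromatic carbon as hydrogen in place of methoxy on an aromatic carbon, ortho to a large group. Among the compounds with values here, two measured steps bear on this change. Within the data shown here, the closest precedent is the same exchange in reverse on the compounds without the methyl on the ring amine nitrogen, no change at the digits printed from compound 1 to compound 3 (within the scatter) for methoxy in place of hydrogen on an aromatic carbon. The other is no change at the digits printed from compound 2 to compound 3 (within the scatter) for hydrogen in place of that methyl. With only these two steps as precedents, no step beyond the scatter is expected in this assay in either direction. The expected step is no change at the digits printed from compound 2 to compound 4 (within the scatter) on this estimate. Compound 4 is estimated at 50 ug/mL within a range from 30 ug/mL to 80 ug/mL for now.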

Compound 4, half-maximal inhibitory concentration: 50 ug/mL
Compound 4: the middle estimate sits on the measured number at the digits printed; the range from low to high includes it.
By their numbers in this assay, from the lowest: compounds 1, 2, 3 and 4 (each within the scatter of the next).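

In this assay, the exchange of methoxy for hydrogen at this position, ortho to a large group, now reads the same with the methyl on the ring amine nitrogen in place as without it, giving no change at the digits printed from compound 2 to compound 4 (within the scatter): the same change on two cores in this assay, no change at the digits printed (within the scatter) from compound 1 to compound 3 and no change at the digits printed (within the scatter) from compound 4 to compound 2, 1.0-fold (0.00 log units) apart, within the scatter of two such steps. The methyl on the ring amine nitrogen likewise reads the same with this methoxy absent, giving no change at the digits printed from compound 1 to compound 4 (within the scatter): the same change on two cores in this assay, no change at the digits printed (within the scatter) from compound 2 to compound 3 and no change at the digits printed (within the scatter) from compound 4 to compound 1, 1.0-fold (0.00 log units) apart, within the scatter of two such steps. Across the four compounds, neither change alters the reading of the other in this assay.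

With all four compounds at one level, the series does not yet show that any change at either place can move this read-out. Open, from the compounds shown here alone, is whether an amine or a carboxylic acid on this aromatic carbon, or a longer chain on the ring amine nitrogen, would give a step beyond the scatter.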